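Moving Fluorine on the Benzyl Group and Cell Tolerance

The source may hold more compounds than are shown below. What is called first, only, known or untested is meant among the compounds shown, and "the series" means these compounds.

Of the compounds shown here, three sharing one core have been measured in an ADME assay on MDCK cells (Canis lupus familiaris) for cytotoxicity, read by microscopy, with a stated time of 72 h; a higher number here means that more compound is tolerated, a lower number that less compound is tolerated. Compound 1 `COC(=O)C[C@H](NC(=O)OC(C)(C)C)C(=O)N(Cc1ccc(F)cc1)C1(C(=O)NCc2ccccc2)CCN(Cc2ccccc2)CC1` carries a 4-fluorobenzyl group on an amide-type nitrogen; in this assay compound 1 reaches the assay's limit of > 100000 nM, which is a limit and not a number. Compound 2 `COC(=O)C[C@H](NC(=O)OC(C)(C)C)C(=O)N(C1CC1)C1(C(=O)NCc2ccccc2)CCN(Cc2ccccc2)CC1`, with cyclopropyl on that nitrogen, gives 84000 nM. Compound 3 `COC(=O)C[C@H](NC(=O)OC(C)(C)C)C(=O)N(Cc1ccccc1F)C1(C(=O)NCc2ccccc2)CCN(Cc2ccccc2)CC1`, with 2-fluorobenzyl there, gives 20000 nM, the lowest of the two numbers shown; its nearest neighbour is compound 2, and the step of a 4.2-fold lower number from compound 2 to compound 3 (0.62 log units; beyond the scatter) runs beyond the scatter, as does an at least 5.0-fold lower number from compound 1 to compound 3 (0.69 log units; beyond the scatter).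

Compound 4 `COC(=O)C[C@H](NC(=O)OC(C)(C)C)C(=O)N(Cc1ccc(F)c(F)c1)C1(C(=O)NCc2ccccc2)CCN(Cc2ccccc2)CC1` has not yet been measured. It differs from compound 3 in one place: 3,4-difluorophenyl in place of 2-fluorophenyl on a saturated chain carbon bound to an amide-type nitrogen. The step that bears most on this change is an at least 5.0-fold lower number from compound 1 to compound 3 (0.69 log units; beyond the scatter), where exchanging 4-fluorophenyl for 2-fluorophenyl lowered the tolerated concentration. Going by the values given here, compound 4 leaves the 2-fluorophenyl arrangement behind and carries a second fluorine instead; a second fluorine on this ring has no measured counterpart among the three compounds. A modest rise in this assay is expected, short of a full return to the limit seen for compound 1.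

Compound 4 is therefore estimated at 50000 nM, expected to fall between 15000 nM and 120000 nM. That estimate means an expected step of a 2.5-fold higher number from compound 3 to compound 4 (0.40 log units; beyond the scatter).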

Compound 4, minimum cytotoxic concentration: 20000 nM
For compound 4 the middle estimate is 2.5-fold (0.40 log units) above the measured one, within the range that was stated.
By their numbers in this assay, from the lowest: compounds 3 and 4 (each within the scatter of the next); then compound 2. At a limit, above all of these: compound 1.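

In this assay, the step of no change at the digits printed from compound 3 to compound 4 (within the scatter) shows that 2-fluorobenzyl and 3,4-difluorobenzyl on the amide-type nitrogen cannot be told apart, and the step of a 4.2-fold lower number from compound 2 to compound 4 (0.62 log units; beyond the scatter) shows that the 3,4-difluorobenzyl group also stands beyond the scatter from cyclopropyl, so the low number of compound 3 is no longer a lone case among the fluorinated benzyl groups. The step of an at least 5.0-fold lower number from compound 1 to compound 4 (0.69 log units; beyond the scatter) adds something new: a single fluoro in place of hydrogen on an aromatic carbon of the 4-fluorobenzyl ring is enough to separate the two compounds, even though that change is small and the 4-fluoro group stays in place. For compound 1 the figure is a limit of the assay and not a number, so the size of that last step is only a floor: the limit of > 100000 nM in this assay, at which 1 of the 4 values shown sits.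

The compounds shown leave open how an unsubstituted benzyl group, or a benzyl ring carrying chlorine or methoxy in place of fluorine, would stand on this nitrogen. They also leave open whether the same pattern would hold with a carboxylic acid in place of the methyl ester elsewhere on the shared core.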